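Swapping Chloro for Bromo on the Benzyl Group

The source may hold more compounds than are shown below. What is called first, only, known or untested is meant among the compounds shown, and "the series" means these compounds.

Three compounds share one core and were tested in an assay on isolated protein for inhibition of serine/threonine-protein kinase PAK 4 (Homo sapiens), read by HTRF, with a stated time of 60 min; on this read-out lower numbers stand for stronger inhibition and higher numbers for weaker inhibition. Compound 1 `Cc1cc(Nc2nc(Nc3ccccc3)nc3[nH]ncc23)n[nH]1` gives 5900 nM. Compound 2 `Cc1cc(Nc2nc(NCc3ccccc3F)nc3[nH]ncc23)n[nH]1` gives 389 nM. Compound 3 `Cc1cc(Nc2nc(NCc3cccc(Cl)c3)nc3[nH]ncc23)n[nH]1` gives 611 nM, the second highest of the three numbers, with compound 2 nearest and compound 1 furthest. Replacing phenyl by a benzyl group mattered: a 15-fold lower number from compound 1 to compound 2 (1.18 log units; beyond the scatter) and a 9.7-fold lower number from compound 1 to compound 3 (0.98 log units; beyond the scatter). By contrast, a 1.6-fold higher number from compound 2 to compound 3 (0.20 log units; within the scatter). Compound 4 `Cc1cc(Nc2nc(NCc3cccc(Br)c3)nc3[nH]ncc23)n[nH]1` differs from compound 3 only by bromo in place of chloro on an aromatic carbon. Going by the values given here, no measured step exchanges one halogen for another at the same place; the only change among the benzyl compounds, from compound 2 to compound 3, stayed within the scatter. Little movement is therefore expected, and a 1.2-fold lower number from compound 3 to compound 4 (0.09 log units; within the scatter) is the estimate. Compound 4 is expected to give 500 nM, between 200 nM and 1500 nM.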

Compound 4, half-maximal inhibitory concentration: 4340 nM
For compound 4 the middle estimate is 8.7-fold (0.94 log units) below the measured one, outside the stated range (above it).
By their numbers in this assay, from the lowest: compounds 2 and 3 (each within the scatter of the next); then compounds 4 and 1 (each within the scatter of the next).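

In this assay bromo in place of chloro gives a 7.1-fold higher number from compound 3 to compound 4 (0.85 log units; beyond the scatter) on this aromatic carbon, so exchanging one halogen for another here is far from a quiet change. The gain seen with the other two benzyl groups does not extend to 3-bromobenzyl: there is only a 1.4-fold lower number from compound 1 to compound 4 (0.13 log units; within the scatter) against phenyl, yet an 11-fold higher number from compound 2 to compound 4 (1.05 log units; beyond the scatter) against 2-fluorobenzyl. Nothing available explains this jump.

From the compounds shown here alone, whether bromo alone behaves this way remains open. The compounds shown do not tell how a methyl or methoxy group would fare at this place.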